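Compound 3 to compound 4: a step from the limit

The source may report more compounds than this note shows. Statements on the series, on what has been measured and on what is new or still open speak of the compounds shown alone.

In an ADME assay on Raji cells (Homo sapiens) for cytotoxicity, read by CellTiter-Glo and resazurin assay, with a stated time of 72 h (on this read-out higher numbers stand for an effect only at larger amounts of compound and lower numbers for an effect already at smaller amounts), compound 3 (`Cc1nnc(-c2cccc(-c3ccc(C(=O)N(Cc4cccc(OCCCCCC(=O)O)c4)C(C)C)cc3)c2)o1`) gives > 26000 nM as a limit of the assay and not a number. Compound 1 (`CC(=O)c1cccc(-c2ccc(C(=O)N(Cc3cccc(OCCCCCC(=O)O)c3)C(C)C)cc2)c1`) gives > 26000 nM as a limit too. Compound 2 (`CC(C)Oc1cccc(-c2ccc(C(=O)N(Cc3cccc(OCCCCCC(=O)O)c3)C(C)C)cc2)c1`) gives > 26000 nM as a limit too. Together these leave the limit of > 26000 nM in this assay, at which 3 of the 3 values shown sit, as the only fixed point of the series.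

Compound 4 (`CC(C)N(Cc1cccc(OCCCCCC(=O)O)c1)C(=O)c1ccc(-c2cccc(OC(F)(F)F)c2)cc1`) carries trifluoromethoxy in place of 5-methyl-1,3,4-oxadiazol-2-yl on an aromatic carbon, meta to a large group (trifluoromethoxy in place of 5-methyl-1,3,4-oxadiazol-2-yl on an aromatic carbon). Three measured changes at that place bear on it. Isopropoxy in place of acetyl is a step that the two limits leave unreadable from compound 1 to compound 2 and gives no size. 5-methyl-1,3,4-oxadiazol-2-yl in place of acetyl is a step that the two limits leave unreadable from compound 1 to compound 3 and gives no size either. The same group in place of isopropoxy is a step that the two limits leave unreadable from compound 2 to compound 3 and is equally silent.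

The expectation rests on compound 3 giving > 26000 nM as a limit and on all three changes ending at a limit. No size beyond the scatter is expected in this assay and no direction is favoured. The estimated step is a step that the limit leaves unreadable from compound 3 to compound 4 and a further limit is the likeliest report. For compound 4 the estimate is 30000 nM and a range from 14000 nM to 60000 nM is expected for it.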

Compound 4, half-maximal effective concentration: > 26000 nM
Compound 4: a limit, no number; the forecaster's own chance of this, stated with the estimate: 85%; the middle value is on the limit's open side.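

In this assay compound 4 gives > 26000 nM, a limit of the assay and not a number. Its steps from compound 1, compound 2 and compound 3 cannot be read. The compounds shown leave open whether any group at this place gives a readable value, and how far these compounds differ from one another: the limit of > 26000 nM in this assay, at which 4 of the 4 values shown sit.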